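The compounds below may be only part of what the source reports. "The series", "measured", "known", "first", "only" and "open" are said of these compounds alone.

Two compounds share a core that carries a tertiary alcohol, a methylthio-linked aromatic ring and a nitro-trifluoromethyl aryl group. Compound 1 `CC(O)(CSc1ccc(F)cc1)c1nc(-c2ccc([N+](=O)[O-])c(C(F)(F)F)c2)no1` bears a fluoro group on the thio-linked ring, and in a functional assay on PC-3 cells (Homo sapiens) for cytotoxicity, read by MTT assay (a higher number here means a weaker inhibitor, a lower number a stronger inhibitor), compound 1 gives 5500 nM. Compound 2 `CC(O)(CSc1ccccc1)c1nc(-c2ccc([N+](=O)[O-])c(C(F)(F)F)c2)no1` has a hydrogen there instead, and in this assay compound 2 gives 3500 nM. The step of a 1.6-fold lower number from compound 1 to compound 2 (0.20 log units; within the scatter) is the only one measured so far, and it does not separate the two compounds. Compound 2 therefore stands with the lower of the two numbers, though its nearest neighbour, compound 1, is within the scatter of it.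

Compound 3 `CC(O)(CSc1ccc(Cl)cc1)c1nc(-c2ccc([N+](=O)[O-])c(C(F)(F)F)c2)no1` is the next point: the difference from compound 2 is chloro in place of hydrogen on an aromatic carbon. For the measured compounds named here, the one step that bears on a substituent at this position, from compound 1 to compound 2, was within the scatter, so no step beyond the scatter is expected in this assay for compound 3 either. The step of no change at the digits printed from compound 2 to compound 3 (within the scatter) is what is expected here. For compound 3, the value in this assay is estimated at 3500 nM, with a range from 1500 nM to 8500 nM.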

Compound 3, half-maximal inhibitory concentration: 3000 nM
For compound 3 the middle estimate is 1.2-fold (0.07 log units) above the measured one; measured number inside the range.
By their numbers in this assay, from the lowest: compounds 3, 2 and 1 (each within the scatter of the next).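

Chloro now joins hydrogen and fluoro as a third occupant of the aromatic carbon para to a large group, and in this assay the change from hydrogen to chloro is a 1.2-fold lower number from compound 2 to compound 3 (0.07 log units; within the scatter), while the direct exchange of one halogen for the other is a 1.8-fold lower number from compound 1 to compound 3 (0.26 log units; within the scatter). For the compounds shown here, the earlier compounds offered only a single comparison at this position, whereas all three pairs can now be read, and none of them is separated beyond the scatter, so hydrogen, fluoro and chloro cannot be told apart here in this cytotoxicity read-out. No independent data are available to explain why these three compounds remain so close.

Going by these compounds, it remains open whether a group of another kind at this position, such as an amine, a carboxylic acid or a methoxy group, would give a step beyond the scatter. The compounds shown also leave open whether the same holds at other carbons of this ring, or when the sulfanyl link, the tertiary alcohol or the nitro and trifluoromethyl substituents are changed.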